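Exchanging 4-methylphenyl for 2-nitrophenyl in a small series

The source may hold more compounds than are shown below. What is called first, only, known or untested is meant among the compounds shown, and "the series" means these compounds.

In a functional assay on OVCAR-3 cells (Homo sapiens) for cytotoxicity, read by sulforhodamine B assay (a higher number here means a weaker inhibitor of growth, a lower number a stronger inhibitor of growth), compound 1 (`CC1=CC[C@@H]([C@@](C)(O)CCCC(C)(C)NC=S)CC1`) gives 12100 nM, compound 2 (`CC1=CC[C@@H]([C@@](C)(O)CCCC(C)(C)NC(=S)NN)CC1`) gives 17200 nM and compound 3 (`CC1=CC[C@@H]([C@@](C)(O)CCCC(C)(C)NC(=S)N/N=C\c2ccc(C)cc2)CC1`) gives 6020 nM. Compound 3 thus stands within the scatter of compound 1 and clearly lower than compound 2. Amino in place of hydrogen on the thiocarbonyl carbon gave a 1.4-fold higher number from compound 1 to compound 2 (0.15 log units; within the scatter), and attaching the aromatic group then gave a 2.9-fold lower number from compound 2 to compound 3 (0.46 log units; beyond the scatter), a modest step. Compound 4 (`CC1=CC[C@@H]([C@@](C)(O)CCCC(C)(C)NC(=S)N/N=C\c2ccccc2[N+](=O)[O-])CC1`) carries 2-nitrophenyl in place of 4-methylphenyl on a carbon with a double bond to nitrogen. Among the compounds with values here, no measured step exchanges one aromatic group for another, so the evidence is indirect. The nearest guide is the modest step that introduced the ring, a 2.9-fold lower number from compound 2 to compound 3 (0.46 log units; beyond the scatter), and an exchange on a ring already present is expected to stay smaller than that. The expected result in this assay is a 1.0-fold lower number from compound 3 to compound 4 (0.00 log units; within the scatter), with no change beyond the scatter. For compound 4 the estimated value is 6000 nM, with an expected range of 2500 nM to 14000 nM.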

Compound 4, concentration for 50% growth inhibition: 7390 nM
Estimate against measurement, compound 4: 1.2-fold (0.09 log units) below, and the stated range covers the measured number.
By their numbers in this assay, from the lowest: compounds 3, 4, 1 and 2 (each within the scatter of the next, the first and the last beyond it).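

In this assay, 2-nitrophenyl in place of 4-methylphenyl on a carbon with a double bond to nitrogen gave a 1.2-fold higher number from compound 3 to compound 4 (0.09 log units; within the scatter) and so left the number unchanged within the scatter. Within the data shown here, this position therefore accepted a second aromatic group with 9 heavy atoms in place of 7 and 2 hydrogen-bond acceptors in place of 0, a change the earlier compounds, with only the 4-methylphenyl ring, did not test. Nothing shown gives a reason for this outcome.

The compounds shown do not separate the effect of the nitro group from that of losing the methyl group, since both changes come together in this one exchange. They also leave open whether an amine or a carboxylic acid on the ring, or a longer chain in place of the ring, would be accepted equally well.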